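Methoxy position and a bromo substituent on a shared core

A few compounds are considered here, and "the series" means these few. Any claim that something is new, unique, unknown or untested is made for them only; others in the source may bear on it.

Compound 1 `COc1cccc(C(=O)n2c(-c3cn(C)c4ccccc34)nc3ccccc32)c1` and compound 2 `COc1ccc(C(=O)n2c(-c3cn(C)c4ccccc34)nc3ccccc32)cc1` share a core; compound 3 `COc1cccc(C(=O)n2c(-c3cn(C)c4ccc(Br)cc34)nc3ccccc32)c1` and compound 4 `COc1ccc(C(=O)n2c(-c3cn(C)c4ccc(Br)cc34)nc3ccccc32)cc1` carry that core with one further substituent. In a functional assay on HepG2 cells (Homo sapiens) for inhibition, read by MTT assay, with a stated time of 24 h (a lower number here means a stronger inhibitor of growth, a higher number a weaker inhibitor of growth), compound 1 gives 13600 nM, compound 2 gives 15200 nM and compound 3 gives 17800 nM. Between compound 1 and compound 2 the change is 4-methoxyphenyl in place of 3-methoxyphenyl on a carbonyl carbon, and it made a 1.1-fold higher number from compound 1 to compound 2 (0.05 log units; within the scatter). The cores of compound 3 and compound 1 differ by bromo in place of hydrogen on an aromatic carbon, which made a 1.3-fold higher number from compound 1 to compound 3 (0.12 log units; within the scatter). Compound 4 differs from compound 3 by 4-methoxyphenyl in place of 3-methoxyphenyl on a carbonyl carbon, the same change as from compound 1 to compound 2, at a place described in the same words. In this assay compound 4 is expected to show a step of about a 1.1-fold higher number from compound 3 to compound 4 (0.04 log units; within the scatter), because the same change gave a 1.1-fold higher number from compound 1 to compound 2 (0.05 log units; within the scatter). The estimate for compound 4 is 19500 nM, with a likely range from 9500 nM to 40000 nM.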

Compound 4, concentration for 50% growth inhibition: 18900 nM
Estimate against measurement, compound 4: 1.0-fold (0.01 log units) above; the range from low to high includes it.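

In this assay, 4-methoxyphenyl in place of 3-methoxyphenyl on a carbonyl carbon gave a 1.1-fold higher number from compound 3 to compound 4 (0.03 log units; within the scatter), and bromo in place of hydrogen on an aromatic carbon gave a 1.2-fold higher number from compound 2 to compound 4 (0.09 log units; within the scatter). The methoxy change reads alike on the two cores: the same change on two cores in this assay, a 1.1-fold higher number (0.05 log units; within the scatter) from compound 1 to compound 2 and a 1.1-fold higher number (0.03 log units; within the scatter) from compound 3 to compound 4, 1.1-fold (0.02 log units) apart, within the scatter of two such steps. For the compounds shown here, the bromo change also repeats, but with every step inside the scatter, this shows only that neither change moved the number on these cores, not that a change of real size would carry over in the same way: the same change on two cores in this assay, a 1.3-fold higher number (0.12 log units; within the scatter) from compound 1 to compound 3 and a 1.2-fold higher number (0.09 log units; within the scatter) from compound 2 to compound 4, 1.1-fold (0.02 log units) apart, within the scatter of two such steps.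

The compounds shown leave open whether an amine or a carboxylic acid in place of the methoxy group would shift the number beyond the scatter. On these data alone, whether chloro or fluoro in place of bromo would do so also remains open.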